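Swapping the ring-nitrogen phenyl for a dimethoxyphenyl

The source may hold more compounds than are shown below. What is called first, only, known or untested is meant among the compounds shown, and "the series" means these compounds.

Measured so far:
compound 1 `O=C(NCCCCc1ccccc1)c1cccc(C2SCC(=O)N2c2ccccc2)c1`: 89%
compound 2 `COc1ccccc1N1C(=O)CSC1c1cc(F)cc(C(=O)O)c1`: 0%

In a functional assay on MG-63 cells (Homo sapiens) for inhibition, read by CCK-8 assay, with a stated time of 72 h, tested at 1 uM (a higher number here means more inhibition at the concentration tested (going by the name of the read-out), a lower number less inhibition), compound 1 gives 89%, the higher of the two numbers, and compound 2 gives 0%. For the measured compounds named here, compound 2 differs from compound 1 in several places at once, so the two values show only that the inhibition of compound 1 in this assay is the higher of the pair. Compound 3 `COc1ccc(N2C(=O)CSC2c2cccc(C(=O)NCCCCc3ccccc3)c2)c(OC)c1` is not yet measured. It keeps the amide chain of compound 1 and changes one place: 2,4-dimethoxyphenyl in place of phenyl on an amide-type nitrogen in a ring. Going by the values given here, with no single-change step to go by, the expectation is a moderate drop a number 17 percentage points lower from compound 1 to compound 3 (beyond the scatter). Compound 3 is expected to give 72%, from 40% to 92%.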

Compound 3, a percentage reported as inhibition, at one concentration (the size of the read-out at that concentration, not a potency): 56%
The estimate for compound 3 lay 16 percentage points above the measured number; low and high end bracket the measured number.
By their numbers in this assay, from the lowest: compound 2; then compound 3; then compound 1.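

Putting 2,4-dimethoxyphenyl in place of phenyl on the amide-type nitrogen in the ring gives a number 33 percentage points lower from compound 1 to compound 3 (beyond the scatter) in this assay, which shows that inhibition at the tested concentration depends on what this position carries. The change lowers inhibition without removing it, as compound 3 still gives 56% in this test. No available measurement gives a reason for the drop.

From the compounds shown here alone, whether one methoxy group alone would give the same step stays open. So does the effect of a hydroxyl or an amine on this phenyl ring.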